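The source may report more compounds than this note shows. Statements on the series, on what has been measured and on what is new or still open speak of the compounds shown alone.

Compound 1, `CC(C)N1C(=O)C(=O)N=C1/N=C(\NCC(C)(C)C)Nc1ccc(Cl)c(Cl)c1`, in an in vitro ADME assay on microsomes from liver (Mus musculus) for metabolic stability, read by LC-MS (on this read-out lower numbers stand for a shorter-lived compound and higher numbers for a longer-lived compound), gives > 1 h, which is a limit of the assay and not a number.
Compound 2, `CC(C)N1C(=O)C(=O)N=C1/N=C(\NCCN1CCCC1)Nc1ccc(Cl)c(Cl)c1`, in this assay gives > 1 h, likewise a limit of the assay.

Compound 2 therefore stands at the upper edge of what this assay reports, as does compound 1: the limit of > 1 h in this assay, at which 2 of the 2 values shown sit. Within the data shown here, the only measured step, a step that the two limits leave unreadable from compound 1 to compound 2, cannot be sized because both of its ends are limits, so it gives no read on how a change at the chain end moves the half-life.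

The next compound, compound 3, `CC(C)N1C(=O)C(=O)N=C1/N=C(\NCCCN(C)C)Nc1ccc(Cl)c(Cl)c1`, differs from compound 2 by (dimethylamino)methyl in place of pyrrolidin-1-yl on a saturated chain carbon, two bonds along the chain from an amine nitrogen. Among the measured compounds shown here, no measured step bears on this change in a readable way; the one step available is hidden by the limits. What can be said is that both measured compounds sit at the limit and that the change keeps the same kind of basic amine at the chain end. Compound 3 is therefore expected to show a step that the limit leaves unreadable from compound 2 to compound 3 in this assay, meaning no movement beyond the scatter. The estimate for compound 3 is 1.5 h, with a range from 0.5 h to 4 h, and most likely the assay will again report only its limit.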

Compound 3, half-life: > 1 h
Compound 3 gave a limit, no number (the forecaster's own chance of this, stated with the estimate: 70%); the middle value lies beyond the limit too.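

In this assay compound 3 gives > 1 h, which is a limit and not a number. Its steps from compound 1 and from compound 2 therefore cannot be read, and all three compounds sit at the same edge: the limit of > 1 h in this assay, at which 3 of the 3 values shown sit.

The compounds shown leave open how long each actually lasts in this assay and whether changing the chain end moves the half-life at all.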